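Allyl to Propyl on a Selenocyanate Carbamate

This account rests on a few compounds, and the source may have more. Where it says the series, first, only, none or still open, it means among the compounds named here.

Measured so far:
Compound 1, `CC(C)COC(=O)Nc1ccc([Se][Se]c2ccc(NC(=O)OCC(C)C)cc2)cc1`: in a functional assay on MCF7 cells (Homo sapiens) for cytotoxicity, read by MTT assay, with a stated time of 72 h (a higher number here means a weaker inhibitor of growth, a lower number a stronger inhibitor of growth), compound 1 gives 49700 nM.
Compound 2, `N#C[Se]c1ccc(NC(=O)Oc2ccc(F)cc2)cc1`: compound 2 gives 33300 nM.
Compound 3, `C=CCOC(=O)Nc1ccc([Se]C#N)cc1`: compound 3 gives 43100 nM.

Compound 3 stands second highest of the three numbers. Its nearest neighbour is compound 1, whose number is a little higher, and compound 2 sits at the other end with a slightly lower number. Both gaps lie within the usual scatter of repeated measurements of this kind, so on these numbers the three compounds cannot be told apart, and none of them can be called stronger or weaker than another.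

Compound 4, `CCCOC(=O)Nc1ccc([Se]C#N)cc1`, has not yet been measured. It differs from compound 3 in one place: ethyl in place of vinyl on a saturated chain carbon bound to an oxygen next to a carbonyl group. Among the measured compounds shown here, no pair of measured compounds differs only in this part of the molecule, so there is no direct guide to how far the number should move. With nothing in the measured set pointing either way, the step of a 1.0-fold higher number from compound 3 to compound 4 (0.02 log units; within the scatter) is expected to be small, with no direction beyond the scatter. Compound 4 is therefore estimated to give 45000 nM, with a range from 25000 nM to 80000 nM.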

Compound 4, concentration for total growth inhibition: 34400 nM
Estimate against measurement, compound 4: 1.3-fold (0.12 log units) above; measured number inside the range.
By their numbers in this assay, from the lowest: compounds 2, 4, 3 and 1 (each within the scatter of the next).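

Among the compounds shown here, the swap of allyl for propyl gives the first step that can be read at this position, and it does so in a matched pair, where only the end of the chain on the carbamate oxygen differs. In this assay, ethyl in place of vinyl gives a 1.3-fold lower number from compound 3 to compound 4 (0.10 log units; within the scatter), so taking away the double bond outside the aromatic ring, with the count of heavy atoms unchanged, does not separate these two compounds, and this one pair gives no sign that the double bond matters to the number in this assay. Nothing available here bears on why the two compounds stay this close, so this result describes the numbers and offers no explanation of them.

The step covers only two chains of similar size, so it leaves open whether a longer chain such as octyl, or a chain ending in an amine or a carboxylic acid, would move the number beyond the scatter. It also rests on a single pair, and whether the same swap behaves alike on another core, such as that of compound 1, remains an open question.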